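A few compounds are considered here, and "the series" means these few. Any claim that something is new, unique, unknown or untested is made for them only; others in the source may bear on it.

Measured in a functional assay on HeLa S3 cells (Homo sapiens) for antiproliferative activity, read by XTT assay, with a stated time of 72 h; a lower number here means a stronger inhibitor, a higher number a weaker inhibitor:
- compound 1 `Cc1nc(N)c2c(-c3cccs3)cn([C@@H]3O[C@H](CO)[C@@H](O)[C@H]3O)c2n1`: > 20000 nM, a limit
- compound 2 `Nc1nc2c(c(-c3ccco3)cn2[C@@H]2O[C@H](CO)[C@@H](O)[C@H]2O)c(=O)[nH]1`: > 20000 nM, a limit
- compound 3 `Nc1nc2c(c(-c3ccoc3)cn2[C@@H]2O[C@H](CO)[C@@H](O)[C@H]2O)c(=O)[nH]1`: 10700 nM, a number

Going by the values given here, compound 3 gives the only number in the set, 10700 nM. Compound 1 and compound 2 share (the limit of > 20000 nM in this assay, at which 2 of the 3 values shown sit).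

The next compound is compound 4 `Nc1nc2c(c(-c3ccccc3)cn2[C@@H]2O[C@H](CO)[C@@H](O)[C@H]2O)c(=O)[nH]1`, with phenyl in place of furan-3-yl on an aromatic carbon of the five-membered aromatic ring with 1 nitrogen: phenyl in place of furan-3-yl on an aromatic carbon.

Among the compounds with values here, no measured step exchanges a furan ring for phenyl. The nearest evidence is the change from furan-2-yl to furan-3-yl, an at least 1.8-fold lower number from compound 2 to compound 3 (0.27 log units; that floor lies within the scatter). Its floor lies within the scatter, so it supports no sizeable expected change. A small move towards a weaker number is expected in this assay, with no gain in potency anticipated. The expected step is a 1.4-fold higher number from compound 3 to compound 4 (0.15 log units; within the scatter), which stays within the scatter. A report of only a limit is about as likely as a number. For compound 4 the estimated value is 15000 nM, with an expected range of 6000 nM to 30000 nM.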

Compound 4, half-maximal inhibitory concentration: > 20000 nM
Compound 4 ended at the assay's limit; the forecaster's own chance of this, stated with the estimate: 50%; middle value at least 1.3-fold (0.12 log units) from the limit.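

In this assay, phenyl in place of furan-3-yl on this aromatic carbon gives an at least 1.8-fold higher number from compound 3 to compound 4 (0.27 log units; that floor lies within the scatter), so the six-membered aromatic ring of carbon only brings no gain in potency over furan-3-yl, while the floor of the step does not establish a real loss. Compound 2 and compound 4 both end at a limit, and the step between them cannot be read. Compound 3 remains the only compound with a number, and the rest of the set gathers at one limit: the limit of > 20000 nM in this assay, at which 3 of the 4 values shown sit.

From the compounds shown here alone, whether an amine, a carboxylic acid or a longer chain on this carbon, in place of the aromatic ring, would give a number in this assay stays open. Also open, going by these compounds, is whether any group here reaches a clearly stronger value than compound 3.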